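Swapping methoxy for hydroxy on compound 2

This account rests on a few compounds, and the source may have more. Where it says the series, first, only, none or still open, it means among the compounds named here.

Measured in a functional assay on NCI-H1299 cells (Homo sapiens) for antiproliferative activity, read by MTT assay, with a stated time of 24 h; on this read-out higher numbers stand for weaker inhibition and lower numbers for stronger inhibition:
- Compound 1 `COc1cc(/C=C/C(=O)NNC(=O)c2ccccc2)cc(OC)c1O` gives > 10000 nM, which is a limit of the assay
- Compound 2 `COc1ccc(C(=O)NNC(=O)/C=C/c2cc(OC)c(O)c(OC)c2)cc1` gives 7450 nM as a true number

For the measured compounds named here, compound 2 holds the only true number so far. Compound 3 `COc1cc(/C=C/C(=O)NNC(=O)c2ccc(O)cc2)cc(OC)c1O` differs from it in one place: hydrogen in place of methyl on an oxygen on an aromatic ring, with hydrogen in place of methyl on an oxygen on an aromatic ring. Going by the values given here, the one measured step, an at least 1.3-fold lower number from compound 1 to compound 2 (0.12 log units; that floor lies within the scatter), puts methoxy in place of hydrogen on an aromatic carbon and does not clear the scatter. On that basis, no step beyond the scatter is expected in this assay, and the estimated change is a 1.2-fold higher number from compound 2 to compound 3 (0.08 log units; within the scatter) for this pair. For compound 3 the expected value is 9000 nM (estimated range 4000 nM to 18000 nM) in this assay here.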

Compound 3, half-maximal inhibitory concentration: 8710 nM
Compound 3: the middle estimate sits 1.0-fold (0.01 log units) above what was measured; the measured number falls inside the stated range.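

Going from 4-methoxyphenyl to 4-hydroxyphenyl in this assay gives a 1.2-fold higher number from compound 2 to compound 3 (0.07 log units; within the scatter), so at this place hydroxy and methoxy cannot be told apart. Hydroxy in place of hydrogen on the aromatic carbon gives an at least 1.1-fold lower number from compound 1 to compound 3 (0.05 log units; that floor lies within the scatter). That step is only a floor, because the value of compound 1 is a limit of the assay: the limit of > 10000 nM in this assay, at which 1 of the 3 values shown sits.

From the compounds shown here alone, whether either oxygen group truly differs from hydrogen here stays open. So does the effect of an amine or a carboxylic acid at this place.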